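The source may hold more compounds than are shown below. What is called first, only, known or untested is meant among the compounds shown, and "the series" means these compounds.

Measured in a functional assay on MDA-MB-361 cells (Homo sapiens) for antiproliferative activity, read by MTT assay, with a stated time of 72 h; a higher number here means a weaker inhibitor, a lower number a stronger inhibitor:
- Compound 1 `O=C1NN=C(c2ccccc2)/C1=C/N[C@@H](CO)C(=O)O`: 105000 nM
- Compound 2 `Cc1cc(N/C=C2\C(=O)N(c3ccccc3)N=C2c2ccccc2)n[nH]1`: 9980 nM
- Compound 3 `O=C1/C(=C\Nc2cc[nH]n2)C(c2ccccc2)=NN1c1ccccc1`: 51000 nM

Compound 3 ranks second highest of the three, with compound 1 higher and compound 2 lower. In compound 4 `O=C(O)[C@H](CO)N/C=C1\C(=O)N(c2ccccc2)N=C1c1ccccc1`, 1-carboxy-2-hydroxyethyl replaces 1H-pyrazol-3-yl on an amine nitrogen: 1-carboxy-2-hydroxyethyl in place of 1H-pyrazol-3-yl on an amine nitrogen. Among the compounds with values here, no measured step covers this change. The one available, a 5.1-fold higher number from compound 2 to compound 3 (0.71 log units; beyond the scatter), is modest and concerns hydrogen in place of methyl on an aromatic carbon, so it bears only loosely. The closest guide is compound 1, which carries the entering group on a different core and gives 105000 nM. A small rise is therefore expected, possibly no larger than the scatter: the estimated step is a 1.5-fold higher number from compound 3 to compound 4 (0.17 log units; within the scatter). For compound 4 the estimated value is 75000 nM, with an expected range of 25000 nM to 200000 nM.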

Compound 4, half-maximal inhibitory concentration: 52800 nM
Estimate against measurement, compound 4: 1.4-fold (0.15 log units) above, and the stated range covers the measured number.
By their numbers in this assay, from the lowest: compound 2; then compounds 3, 4 and 1 (each within the scatter of the next, the first and the last beyond it).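

In this assay, 1-carboxy-2-hydroxyethyl in place of 1H-pyrazol-3-yl on this amine nitrogen leaves the number within the scatter (a 1.0-fold higher number from compound 3 to compound 4 (0.02 log units; within the scatter)), so an open chain and an aromatic ring read alike here, while compound 2, with 5-methyl-1H-pyrazol-3-yl, stays apart (a 5.3-fold higher number from compound 2 to compound 4 (0.72 log units; beyond the scatter)). With this chain in place, phenyl in place of hydrogen on the amide-type nitrogen in a ring also stays within the scatter (a 2.0-fold lower number from compound 1 to compound 4 (0.30 log units; within the scatter)). No evidence is available to explain these results.

The compounds shown leave open whether a primary amide in place of the carboxylic acid, or a longer chain on this nitrogen, would shift the number.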